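Amide replacement on the shared core: compound 3

This account rests on a few compounds, and the source may have more. Where it says the series, first, only, none or still open, it means among the compounds named here.

compound 1 `CCCn1c(NC(=O)c2ccnn2CC)nc2cc(C(N)=O)cc(OC)c21`: > 100000 nM
compound 2 `CCn1nccc1C(=O)Nc1nc2cc(C(N)=O)cc(OC)c2n1CCCNC(=O)OCc1ccccc1`: > 100000 nM

In an assay for activation of interferon regulatory factor 3 (Homo sapiens), read by a luciferase reporter, with a stated time of 20 h (a higher number here means that more compound is needed for the effect, a lower number that less compound is needed), neither measured compound gives a number. For compound 1 the value > 100000 nM is a limit of the assay. For compound 2 the value > 100000 nM is likewise a limit, so compound 2 stands at the same ceiling as its neighbour. The step that the two limits leave unreadable from compound 1 to compound 2 cannot be read, as both values sit at the limit of > 100000 nM in this assay, at which 2 of the 2 values shown sit.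

Compound 3 `COc1cc(C(N)=O)cc2nc(NC(=O)C3CCCN3C)n(CCCNC(=O)OCc3ccccc3)c12` differs from compound 2 by 1-methylpyrrolidin-2-yl in place of 1-ethyl-1H-pyrazol-5-yl on a carbonyl carbon. Going by the values given here, no measured step bears on this change, and the series offers no readable effect of any kind. Compound 3 is therefore expected at 150000 nM (range 40000 nM to 600000 nM), most probably again reported as a limit. The expected step that the limit leaves unreadable from compound 2 to compound 3 is none beyond the scatter.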

Compound 3, half-maximal effective concentration: > 100000 nM
Compound 3: only a limit was reported (the forecaster's own chance of this, stated with the estimate: 80%); the middle value does not contradict the limit.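

Compound 3 gives > 100000 nM as a limit of the assay, so no step from compound 2 to compound 3 can be read: the limit of > 100000 nM in this assay, at which 3 of the 3 values shown sit.

As far as these compounds go, whether any change on the shared core gives a readable number in this assay stays open.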